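The source may report more compounds than this note shows. Statements on the series, on what has been measured and on what is new or still open speak of the compounds shown alone.

Working notes on a short ester series built on a shared core, followed in an ADME assay on Vero cells (Chlorocebus sabaeus) for cytotoxicity, read by MTT assay; on this read-out lower numbers stand for stronger inhibition and higher numbers for weaker inhibition. Compound 1 (`CCCCCC(=O)OCC(C)(C)CC1=C(O)C(=O)c2ccccc2C1=O`) gives 169000 nM, compound 2 (`CCCCCCC(=O)OCC(C)(C)CC1=C(O)C(=O)c2ccccc2C1=O`) gives 99300 nM, and compound 3 (`CCCCCCCCC(=O)OCC(C)(C)CC1=C(O)C(=O)c2ccccc2C1=O`) gives 150000 nM. Compound 2 stands within the scatter of both other compounds, so the three values do not separate. The steps among them are a 1.7-fold lower number from compound 1 to compound 2 (0.23 log units; within the scatter), a 1.5-fold higher number from compound 2 to compound 3 (0.18 log units; within the scatter) and a 1.1-fold lower number from compound 1 to compound 3 (0.05 log units; within the scatter).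

Compound 4 (`CCCCCCCCCCCCCCCCCC(=O)OCC(C)(C)CC1=C(O)C(=O)c2ccccc2C1=O`) has not yet been measured in this assay. The change from compound 2 is undecyl in place of hydrogen on a saturated chain carbon, six bonds along the chain from a carbonyl carbon. The closest measured precedent is ethyl at that same place, a 1.5-fold higher number from compound 2 to compound 3 (0.18 log units; within the scatter). The propyl change, a 1.1-fold lower number from compound 1 to compound 3 (0.05 log units; within the scatter), points the same way, with no shift beyond the scatter. Undecyl is far larger than either group, and no measured compound carries a chain this long, so the step is an extrapolation and the range has to stay wide. No step beyond the scatter is expected in this assay, and no direction can be called with confidence. The estimated shift is a 1.3-fold higher number from compound 2 to compound 4 (0.12 log units; within the scatter). For compound 4 the expected value is 130000 nM, with an estimated range of 50000 nM to 350000 nM.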

Compound 4, half-maximal inhibitory concentration: 15500 nM
Estimate against measurement, compound 4: 8.4-fold (0.92 log units) above; measured number outside the range, below it.
By their numbers in this assay, from the lowest: compound 4; then compounds 2, 3 and 1 (each within the scatter of the next).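

In this assay the place on a saturated chain carbon, six bonds along the chain from a carbonyl carbon, turns out to respond to chain length: undecyl in place of hydrogen gives a 6.4-fold lower number from compound 2 to compound 4 (0.81 log units; beyond the scatter) and so moves beyond the scatter, which none of the steps among compounds 1, 2 and 3 did. The other two routes to compound 4 agree, with nonyl at eight bonds along the chain giving a 9.7-fold lower number from compound 3 to compound 4 (0.99 log units; beyond the scatter) and dodecyl at five bonds giving an 11-fold lower number from compound 1 to compound 4 (1.04 log units; beyond the scatter) so that compound 4 alone separates from the group, while ethyl and propyl left the number within the scatter. Nothing at hand bears on what lies behind this shift.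

Where between the chains of compound 3 and compound 4 the shift sets in stays open, as does whether it builds gradually or appears abruptly, and whether a longer chain would carry it further. Also open, from the compounds shown here alone, is whether an amine or a carboxylic acid at the far end of the chain would keep the shift or remove it.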